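Amide aryl swap: methoxyphenyl to acetylphenyl on the shared core

The source may report more compounds than this note shows. Statements on the series, on what has been measured and on what is new or still open speak of the compounds shown alone.

Three anilides built on one shared core have been measured in a functional assay on CHO cells for antagonist activity at Orexin receptor type 2 (Homo sapiens), read by FLIPR and calcium flux; a higher number here means a weaker inhibitor, a lower number a stronger inhibitor. Compound 1 `Cc1ccc(C)c(NC(=O)CSc2nnc(-c3ccoc3C)n2Cc2ccco2)c1` gives 398 nM, compound 2 `Cc1cccc(NC(=O)CSc2nnc(-c3ccoc3C)n2Cc2ccco2)c1` gives 50.1 nM, and compound 3 `COc1ccc(NC(=O)CSc2nnc(-c3ccoc3C)n2Cc2ccco2)cc1` gives 200 nM. Compound 3 thus stands second highest of the three numbers; its nearest neighbour is compound 1, differing within the scatter, while compound 2 lies further away, as the step of a 4.0-fold higher number from compound 2 to compound 3 (0.60 log units; beyond the scatter) shows.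

Compound 4 `CC(=O)c1cccc(NC(=O)CSc2nnc(-c3ccoc3C)n2Cc2ccco2)c1` has not yet been measured. It differs from compound 3 by 3-acetylphenyl in place of 4-methoxyphenyl on an amide-type nitrogen. The step that bears on this is a 4.0-fold higher number from compound 2 to compound 3 (0.60 log units; beyond the scatter), which shows that a 3-methylphenyl on the amide nitrogen gave a modestly lower number than 4-methoxyphenyl. Going by the values given here, no measured compound carries an acetyl group, so the expectation rests on that one step alone. Compound 4 is therefore expected to show a modest lowering, a 2.0-fold lower number from compound 3 to compound 4 (0.30 log units; within the scatter), in this assay. Compound 4 is estimated at 100 nM, with a range from 30 nM to 400 nM.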

Compound 4, inhibition constant: 316 nM
Beside the measured number, compound 4's estimate is 3.2-fold (0.50 log units) below it; the measured number falls inside the stated range.
By their numbers in this assay, from the lowest: compound 2; then compounds 3, 4 and 1 (each within the scatter of the next).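

In this assay, going by these compounds alone, the step with acetyl in place of methyl is the first measured change to the substituent of the 3-methylphenyl group itself, and it costs clearly: a 6.3-fold higher number from compound 2 to compound 4 (0.80 log units; beyond the scatter). Exchanging 4-methoxyphenyl for 3-acetylphenyl, by contrast, gives no readable change, with a 1.6-fold higher number from compound 3 to compound 4 (0.20 log units; within the scatter), and the same holds against the 2,5-dimethylphenyl group, with a 1.3-fold lower number from compound 1 to compound 4 (0.10 log units; within the scatter). Compound 2 thus remains the strongest of the four, its steps to all three others lying beyond the scatter, while compounds 1, 3 and 4 cannot be told apart on these steps.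

No supporting data are available to explain why acetyl fares worse than methyl here. From the compounds shown here alone, whether an amine, a carboxylic acid or a longer chain in that same place would keep the number of compound 2 or lose it stays open.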